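A few compounds are considered here, and "the series" means these few. Any claim that something is new, unique, unknown or untested is made for them only; others in the source may bear on it.

Measured in an ADME assay on HEK-293T cells (Homo sapiens) for cytotoxicity, read by luminescence and CellTiter-Glo, with a stated time of 24 h; a lower number here means that less compound is tolerated, a higher number that more compound is tolerated:

- compound 1 `CCCNC(=O)C1CCN(C(=O)c2cc3sc(-c4ccccc4)nc3n2Cc2ccc(OC)cc2)CC1` gives 22900 nM
- compound 2 `CCCNC(=O)C1CCN(C(=O)c2cc(Br)cn2Cc2ccc(OC)cc2)CC1` gives 55000 nM
- compound 3 `CCCNC(=O)C1CC12CN(C(=O)c1cc3sc(Br)cc3n1Cc1ccc(OC)cc1)C2` gives > 100000 nM

Of the two actual numbers, compound 1 stands lowest in this assay; the nearest is compound 2, whose higher number lies beyond the scatter. Compound 3 reports a limit of the assay rather than a number, so it is only known to sit at the limit of > 100000 nM in this assay, at which 1 of the 3 values shown sits.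

Compound 4 `CCCNC(=O)C1CCN(C(=O)c2cc3sc(Br)nc3n2Cc2ccc(OC)cc2)CC1` is compound 1 with one change on the shared core: bromo in place of phenyl on an aromatic carbon. Among the measured compounds shown here, no measured pair differs by this change alone. Both other measured compounds carry bromo and both tolerate more compound than compound 1, so for compound 4 the step of a 2.6-fold higher number from compound 1 to compound 4 (0.42 log units; beyond the scatter) is expected to go toward a higher number, beyond the scatter but of modest size. Compound 4 is thus estimated at 60000 nM in this assay, with a range from 25000 nM to 150000 nM, and a real chance that only a limit is reported.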

Compound 4, half-maximal cytotoxic concentration: 36700 nM
Compound 4: middle estimate off by 1.6-fold (0.21 log units), on the high side; the measured number falls inside the stated range.
By their numbers in this assay, from the lowest: compounds 1, 4 and 2 (each within the scatter of the next, the first and the last beyond it). At a limit, above all of these: compound 3.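

In this assay this position, on the five-membered aromatic ring with 1 nitrogen and 1 sulfur, next to the ring nitrogen and next to the ring sulfur, now has a direct reading: bromo in place of phenyl gives a 1.6-fold higher number from compound 1 to compound 4 (0.20 log units; within the scatter). Removing the phenyl therefore does not shift the number beyond the scatter on this core, which compound 2 and compound 3 could not show, as each differs from compound 1 in more than one place. Nothing measured here gives a cause for this step.

From the compounds shown here alone, whether an amine, a carboxylic acid or a longer chain on this carbon would also stay within the scatter remains open. Among the compounds shown here, whether bromo in place of phenyl behaves alike on another core also stays open, as this is the only such pair.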